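Methoxy for fluoro on the pendant phenyl ring

The source may hold more compounds than are shown below. What is called first, only, known or untested is meant among the compounds shown, and "the series" means these compounds.

Measured so far:
compound 1, `Cc1ccc(-c2ccc(C)n2-c2ccc(-c3nc4ccccc4s3)cc2)cc1`: 17800 nM
compound 2, `Cc1ccc(-c2ccc(F)cc2)n1-c1ccc(-c2nc3ccccc3s2)cc1`: 11800 nM

Both compounds share the same core and were tested in a functional assay on MDA-MB-231 cells (Homo sapiens) for cytotoxicity, read by MTT assay, with a stated time of 72 h; a lower number here means a stronger inhibitor, a higher number a weaker inhibitor. Among the measured compounds shown here, compound 1 gives 17800 nM and compound 2 gives 11800 nM; the two numbers lie within the scatter of each other, as the single measured step shows: a 1.5-fold lower number from compound 1 to compound 2 (0.18 log units; within the scatter). Compound 2 therefore stands on no firm ground apart from compound 1.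

Compound 3, `COc1ccc(-c2ccc(C)n2-c2ccc(-c3nc4ccccc4s3)cc2)cc1`, differs from compound 2 in one place: methoxy in place of fluoro on an aromatic carbon. For the measured compounds named here, only the step from compound 1 to compound 2 bears on this change, and it stayed within the scatter, so nothing here points to a step beyond the scatter in either direction. The expected step is a 1.3-fold higher number from compound 2 to compound 3 (0.10 log units; within the scatter). Compound 3 is estimated at 15000 nM, with a range from 6000 nM to 40000 nM.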

Compound 3, half-maximal inhibitory concentration: 14800 nM
For compound 3 the middle estimate is 1.0-fold (0.01 log units) above the measured one; the measured number falls inside the stated range.
By their numbers in this assay, from the lowest: compounds 2, 3 and 1 (each within the scatter of the next).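

In this assay, going from 4-fluorophenyl to 4-methoxyphenyl gives a 1.3-fold higher number from compound 2 to compound 3 (0.10 log units; within the scatter), and methoxy in place of methyl on the same aromatic carbon gives a 1.2-fold lower number from compound 1 to compound 3 (0.08 log units; within the scatter). Among the compounds shown here, this place, para to a large group, has now carried fluoro, methyl and methoxy, the last bringing a hydrogen-bond acceptor and one more heavy atom than fluoro, and no step among the three compounds leaves the scatter. No evidence on the cause of this accompanies the result.

From the compounds shown here alone, whether any group on this carbon can separate itself from these three remains open. An amine, a carboxylic acid or a longer chain such as butoxy could test this, and the compounds shown give no indication of what such groups would do.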